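Replacing the 2,4-dichlorophenyl on sulfur in compound 3

The compounds below may be only part of what the source reports. "The series", "measured", "known", "first", "only" and "open" are said of these compounds alone.

In a functional assay on MCF7 cells (Homo sapiens) for antiproliferative activity, read by sulforhodamine B assay, with a stated time of 3 days (on this read-out lower numbers stand for stronger inhibition and higher numbers for weaker inhibition), compound 1 `c1nc(OCC2CCCCC2)c2nc[nH]c2n1` gives 32300 nM and compound 2 `Fc1ccc(Sc2ncnc3[nH]cnc23)cc1` gives 31600 nM as its reading. These two values lie within the scatter of each other. Compound 3 `Clc1ccc(Sc2ncnc3ncn(C4COc5ccccc5CO4)c23)c(Cl)c1` gives 8400 nM as the lowest of the three numbers, and its gap to each of the other two lies beyond the scatter.

The next compound to be read is compound 4 `CSc1ncnc2ncn(C3COc4ccccc4CO3)c12` and it differs from compound 3 by one change: methyl in place of 2,4-dichlorophenyl on a sulfur.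

For the measured compounds named here, no measured pair isolates this change, so any forecast is weakly supported. The substituent that compound 3 and compound 4 share on the core is absent from compound 1 and compound 2. That leaves compound 3 at 8400 nM as the only anchor for the expectation. With the aromatic ring gone from the sulfur, a moderate loss of inhibition seems more likely than a gain. The estimated step in this assay is a 1.8-fold higher number from compound 3 to compound 4 (0.25 log units; within the scatter) and is expected to point toward weaker inhibition, though a step within the scatter remains possible. Compound 4 is estimated at 15000 nM with 5000 nM to 40000 nM as its expected range.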

Compound 4, half-maximal inhibitory concentration: 31800 nM
Estimate against measurement, compound 4: 2.1-fold (0.33 log units) below; the measured number falls inside the stated range.
By their numbers in this assay, from the lowest: compound 3; then compounds 2, 4 and 1 (each within the scatter of the next).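

In this assay, for the compounds shown here, methyl in place of 2,4-dichlorophenyl on a sulfur gives a 3.8-fold higher number from compound 3 to compound 4 (0.58 log units; beyond the scatter), the first step that isolates a single change. With the rest of the structure held fixed, the reading of compound 3 at 8400 nM therefore depends in part on the group on the sulfur and is not carried by the remaining structure alone. No measurement at hand explains this step.

The change removes the six-membered aromatic ring and both chlorines together, so the step does not show which of these parts accounts for the difference, and a plain phenyl or a 4-chlorophenyl on the sulfur would separate them. On these data alone, it also remains open whether a non-aromatic group larger than methyl, such as cyclohexyl or a longer chain such as n-butyl, would give a reading nearer to that of compound 3 or to that of compound 4.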